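The source may hold more compounds than are shown below. What is called first, only, known or untested is meant among the compounds shown, and "the series" means these compounds.

Measured so far:
- Compound 1, `O=c1[nH]c2ccccc2n1CCCN1CCC(=C(c2ccccc2)c2ccccc2)CC1`: in an assay on RPMI-8226 cells for antagonist activity at P2X purinoceptor 7 (Homo sapiens), read by calcium flux (on this read-out lower numbers stand for stronger inhibition and higher numbers for weaker inhibition), compound 1 gives 2400 nM.
- Compound 2, `Cc1cccc2c1ccn2CCCCN1CCN(C(c2ccccc2)c2ccccc2)CC1`: in this assay compound 2 gives 5300 nM.

Compound 2 therefore stands at the higher of the two numbers, meaning it is the weaker inhibitor of the pair; its gap to compound 1 is beyond the usual scatter of this kind of measurement, so the two compounds are genuinely distinct on this read-out.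

Compound 3, `COc1ccc2c(ccn2CCCCN2CCN(C(c3ccccc3)c3ccccc3)CC2)c1`, is the next compound to be tested in this assay. It differs from compound 2 in one place: a group of 11 heavy atoms (9 carbon, 1 nitrogen, 1 oxygen; one five-membered aromatic ring with 1 hetero atom, one six-membered aromatic ring of carbon only) in place of a group of 10 heavy atoms (9 carbon, 1 nitrogen; one five-membered aromatic ring with 1 hetero atom, one six-membered aromatic ring of carbon only), on a saturated chain carbon, four bonds along the chain from an amine nitrogen in a ring. The part of the molecule that carries the piperazine and the diphenylmethyl group is unchanged, so the change is confined to the aromatic end of the chain.

Among the compounds with values here, no pair of measured compounds differing in only this way is available, so nothing from the data fixes the size of this step. The expectation is a small change in this assay, most likely within the scatter, with a slight lean toward a lower number. The estimated step from compound 2 to compound 3 is a 1.3-fold lower number from compound 2 to compound 3 (0.12 log units; within the scatter). For compound 3 the estimate is 4000 nM, with a likely range from 1500 nM to 12000 nM.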

Compound 3, half-maximal inhibitory concentration: > 10000 nM
Compound 3 gave a limit, no number; the forecaster's own chance of this, stated with the estimate: 5%; middle value at least 2.5-fold (0.39 log units) away from the limit.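

In this assay compound 3 gives > 10000 nM, which is a limit of the assay and not a number. Putting 5-methoxy-1H-indol-1-yl on the saturated chain carbon, four bonds along the chain from an amine nitrogen in a ring, gives an at least 1.8-fold higher number from compound 2 to compound 3 (0.27 log units; that floor lies within the scatter). As far as these compounds go, this fixes the direction of the change at this position, since the added methoxy group brought no stronger inhibition, but the size of the step stays unknown and its floor alone does not separate the two compounds beyond the scatter, because the result is only a limit: the limit of > 10000 nM in this assay, at which 1 of the 3 values shown sits.

The compounds shown leave open whether the loss belongs to the methoxy group itself or to any added group at this place, and a smaller substituent such as fluorine or a hydroxyl group in its place would help to tell these apart. They also leave open whether a shorter or longer chain would change how 5-methoxy-1H-indol-1-yl behaves in this assay.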